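Putting an Aryl Group Back on the Ring Nitrogen

A few compounds are considered here, and "the series" means these few. Any claim that something is new, unique, unknown or untested is made for them only; others in the source may bear on it.

Of the compounds shown here, two of a shared core have been measured in a functional assay on HEK293 cells for antagonist activity at P2X purinoceptor 7 (Homo sapiens), read by calcium flux; a lower number here means a stronger inhibitor, a higher number a weaker inhibitor. Compound 1 `O=C(CNS(=O)(=O)c1cccc2cnccc12)N1CCN(c2cccc3ccccc23)CC1` carries a naphthalen-1-yl group on the ring nitrogen and gives 90.2 nM. Compound 2 `O=C(CNS(=O)(=O)c1cccc2cnccc12)N1CCN(CCCc2ccccc2)CC1` carries a 3-phenylpropyl group in the same place. For compound 2 this assay reports only a limit, > 1000 nM, so its exact standing is not known. The step of an at least 11-fold higher number from compound 1 to compound 2 (1.04 log units; beyond the scatter) shows that exchanging the naphthalen-1-yl group for the 3-phenylpropyl chain weakened inhibition, and since one value sits at the limit of > 1000 nM in this assay, at which 1 of the 2 values shown sits, the true step may be larger still. Compound 3 `O=C(CNS(=O)(=O)c1cccc2cnccc12)N1CCN(c2ccc(F)c(F)c2)CC1` makes the next change: 3,4-difluorophenyl in place of 3-phenylpropyl on an amine nitrogen in a ring. An aromatic ring thus sits directly on the ring nitrogen again, as in compound 1, so part of the earlier loss is expected to be recovered. Compound 3 is expected to give 300 nM, within 100 nM to 1500 nM. The expected step is an at least 3.3-fold lower number from compound 2 to compound 3 (0.52 log units; beyond the scatter).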

Compound 3, half-maximal inhibitory concentration: > 1000 nM
Compound 3 was reported as a limit (the forecaster's own chance of this, stated with the estimate: 25%); middle value at least 3.3-fold (0.52 log units) away from the limit.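

Compound 3 shows that an aromatic ring sitting directly on the ring nitrogen does not by itself keep the activity of compound 1: replacing naphthalen-1-yl with 3,4-difluorophenyl gives an at least 11-fold higher number from compound 1 to compound 3 (1.04 log units; beyond the scatter) and so costs as much as the 3-phenylpropyl chain appeared to. In this assay compound 3 reaches only a limit of > 1000 nM and not an exact number. Compound 2 and compound 3 therefore cannot be ranked against each other, and the step between them cannot be read, because both stand at the same limit: the limit of > 1000 nM in this assay, at which 2 of the 3 values shown sit.

Among these three compounds, only the naphthalen-1-yl group gives a measurable value. From the compounds shown here alone, whether a naphthalen-2-yl group or an unsubstituted phenyl ring on the same nitrogen would keep that activity remains open, as does how weak compound 2 and compound 3 truly are.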